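This account rests on a few compounds, and the source may have more. Where it says the series, first, only, none or still open, it means among the compounds named here.

Measured in a functional assay on HCT-116 cells (Homo sapiens) for inhibition, read by MTT assay, with a stated time of 48 h; on this read-out lower numbers stand for stronger inhibition and higher numbers for weaker inhibition:
- compound 1 `COc1ccc(CNc2cc(OC)c(OC)c(OC)c2)cc1[N+](=O)[O-]`: 18200 nM
- compound 2 `COCC(=O)N(Cc1ccc(OC)c(O)c1)c1cc(OC)c(OC)c(OC)c1`: 230 nM
- compound 3 `COc1ccc(CNc2cc(OC)c(OC)c(OC)c2)cc1Cl`: 41700 nM

Of these three, compound 3 has the highest number and is therefore the weakest. Compound 1 lies closest to it and compound 2 furthest away. The next compound to be tested is compound 4 `COC(=O)c1cc(CNc2cc(OC)c(OC)c(OC)c2)ccc1OC`, which carries methoxycarbonyl in place of chloro on an aromatic carbon, ortho to a methoxy group and meta to a large group: methoxycarbonyl in place of chloro on an aromatic carbon.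

Among the measured compounds shown here, only one measured step bears on this change: a 2.3-fold higher number from compound 1 to compound 3 (0.36 log units; beyond the scatter). There, chloro replaced nitro on the same aromatic carbon, and the shift was modest. Compound 2 differs from the others in more than one place, so it offers no direct guide. For the measured compounds named here, no measured compound yet carries methoxycarbonyl, so the direction is uncertain, but a modest step is expected in this assay. The estimated result is a 1.7-fold lower number from compound 3 to compound 4 (0.22 log units; within the scatter). Compound 4 is expected at about 25000 nM, within an estimated range of 9000 nM to 70000 nM.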

Compound 4, half-maximal inhibitory concentration: 38100 nM
Compound 4: the middle estimate sits 1.5-fold (0.18 log units) below what was measured; the measured number falls inside the stated range.
By their numbers in this assay, from the lowest: compound 2; then compound 1; then compounds 4 and 3 (each within the scatter of the next).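

At this aromatic carbon, ortho to a methoxy group, the larger methoxycarbonyl takes the place of a single chlorine with a 1.1-fold lower number from compound 3 to compound 4 (0.04 log units; within the scatter), so these two groups cannot be told apart here, even though methoxycarbonyl brings 2 hydrogen-bond acceptors and chloro brings none. Replacing nitro with methoxycarbonyl gives a 2.1-fold higher number from compound 1 to compound 4 (0.32 log units; beyond the scatter), a modest step in the same direction as a 2.3-fold higher number from compound 1 to compound 3 (0.36 log units; beyond the scatter), which leaves compound 1 with the lowest number of the three compounds that differ at this carbon. Nothing available explains these results.

On these data alone, it remains open whether a different group at this carbon, such as an amine or a carboxylic acid, would give a clearly lower number. As far as these compounds go, compound 2 differs from these compounds in more than one place, so the source of its much lower number also remains open.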